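Swapping a pyridine into a weaker chalcone core

A few compounds are considered here, and "the series" means these few. Any claim that something is new, unique, unknown or untested is made for them only; others in the source may bear on it.

Compound 1 `COc1ccc(/C=C/C(=O)c2ccccc2-c2ccc(F)cc2)cc1`: 93 nM
Compound 2 `COc1ccc(/C=C/C(=O)c2ccccc2-c2ccc(F)nc2)cc1`: 290 nM
Compound 3 `COc1ccc(C(=O)/C=C/c2ccccc2-c2ccc(F)cc2)cc1`: 6300 nM

In a functional assay on HepG2 cells (Homo sapiens) for antiproliferative activity, read by sulforhodamine B assay, with a stated time of 48 h (on this read-out lower numbers stand for stronger inhibition and higher numbers for weaker inhibition), compound 1 gives 93 nM, and compound 2 gives 290 nM. The change between them, (6-fluoropyridin-3-yl in place of 4-fluorophenyl on an aromatic carbon), produced a 3.1-fold higher number from compound 1 to compound 2 (0.49 log units; beyond the scatter). Compound 3 has the same atoms as compound 1 joined differently; the difference between the two cores is not broken down here. In this assay compound 3 gives 6300 nM, the highest of the three numbers.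

Compound 4 `COc1ccc(C(=O)/C=C/c2ccccc2-c2ccc(F)nc2)cc1` carries the same change on the core of compound 3: 6-fluoropyridin-3-yl in place of 4-fluorophenyl on an aromatic carbon. Both changes sit ortho to a large group, so they are the same change. Since compound 3 already starts from 6300 nM, the step is expected to be similar, a 2.4-fold higher number from compound 3 to compound 4 (0.38 log units; beyond the scatter), resting on the earlier 3.1-fold higher number from compound 1 to compound 2 (0.49 log units; beyond the scatter) alone. Compound 4 is estimated at 15000 nM, with a likely range from 5000 nM to 45000 nM.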

Compound 4, half-maximal inhibitory concentration: 8200 nM
Estimate against measurement, compound 4: 1.8-fold (0.26 log units) above; the measured number falls inside the stated range.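

Placing 6-fluoropyridin-3-yl where 4-fluorophenyl stood gave a 1.3-fold higher number from compound 3 to compound 4 (0.11 log units; within the scatter) in this assay. Set beside the same change on the core of compound 1, the two steps cannot be told apart: the same change on two cores in this assay, a 3.1-fold higher number (0.49 log units; beyond the scatter) from compound 1 to compound 2 and a 1.3-fold higher number (0.11 log units; within the scatter) from compound 3 to compound 4, 2.4-fold (0.38 log units) apart, within the scatter of two such steps. The change therefore carries from one core to the other without a detectable difference in its size, but two pairs do not prove that the size is equal, and they say nothing about any further core.

The compounds shown leave open whether the same holds for other groups in this place, such as an unsubstituted pyridin-3-yl or a phenyl ring carrying an amine or a carboxylic acid instead of the fluorine. They also leave open how either core behaves in other cell lines.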